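The source may report more compounds than this note shows. Statements on the series, on what has been measured and on what is new or still open speak of the compounds shown alone.

In a functional assay on HL-60 cells (Homo sapiens) for antiproliferative activity, with a stated time of 72 h (on this read-out higher numbers stand for weaker inhibition and lower numbers for stronger inhibition), compound 1 `OC[C@H]1O[C@@H](n2cnc3c(NCc4ccccc4F)ncnc32)[C@H](O)[C@@H]1O` gives 3200 nM as its result, and compound 2 `OC[C@H]1O[C@@H](n2cnc3c(NCc4ccccc4Br)ncnc32)[C@H](O)[C@@H]1O` gives 6600 nM on the same read-out. Among the measured compounds shown here, the one measured step is a 2.1-fold higher number from compound 1 to compound 2 (0.31 log units; beyond the scatter) and counts as modest; it is bromo in place of fluoro on an aromatic carbon. Compound 3 `OC[C@H]1O[C@@H](n2cnc3c(NCc4ccccc4OC(F)F)ncnc32)[C@H](O)[C@@H]1O` stands at "not determined" (no result reported) in this assay and so offers no number to step from. The change to compound 4 `OC[C@H]1O[C@@H](n2cnc3c(NCc4ccccc4OC(F)(F)F)ncnc32)[C@H](O)[C@@H]1O` is fluoro in place of hydrogen on a saturated chain carbon bound to two fluorine atoms and an oxygen on an aromatic ring and turns difluoromethoxy into trifluoromethoxy. For the measured compounds named here, no measured step covers this change, so the bromo for fluoro step bears on it only indirectly, as the one available size of change. As far as these compounds go, with no number for compound 3, no direction can be expected, and the size of the step stays unknown. The expectation rests on the level of compound 1 and compound 2 alone, with compound 4 expected to fall in the same general region. For compound 4 the estimated value is 5000 nM with an expected range from 1800 nM to 14000 nM on this read-out.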

Compound 4, half-maximal inhibitory concentration: > 166000 nM
Compound 4 was reported as a limit (the forecaster's own chance of this, stated with the estimate: 10%); middle value at least 33-fold (1.52 log units) away from the limit.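

In this assay compound 4 is reported only as a limit, not as a number: the limit of > 166000 nM in this assay, at which 1 of the 4 values shown sits. Even so, the gaps it opens are of another size than the earlier one: an at least 25-fold higher number from compound 2 to compound 4 (1.40 log units; beyond the scatter) and an at least 51-fold higher number from compound 1 to compound 4 (1.71 log units; beyond the scatter), against a 2.1-fold higher number from compound 1 to compound 2 (0.31 log units; beyond the scatter). The group on this aromatic carbon can therefore move the read-out far more than the bromo for fluoro change suggested, and trifluoromethoxy sits well on the weak side of both halogens.

As far as these compounds go, the step from compound 3 to compound 4 cannot be read, so what fluoro in place of hydrogen does on this saturated chain carbon stays open. Also open, from the compounds shown here alone, is whether a methoxy group or an amine on the same aromatic carbon would stay near compound 1 and compound 2 or move towards compound 4.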